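Swapping a fluorobenzyl for a phenylethyl on sulfur

The compounds below may be only part of what the source reports. "The series", "measured", "known", "first", "only" and "open" are said of these compounds alone.

Of the compounds shown here, two have been measured in an ADME assay on microsomes from liver (Mus musculus, strain CD-1) for metabolic stability, read by LC-MS, with a stated time of 60 min, tested at 20 uM; on this read-out lower numbers stand for a shorter-lived compound and higher numbers for a longer-lived compound. Compound 1 `O=c1c2cn(C3COC3)nc2nc(SCc2cccc(F)c2)n1-c1ccccc1` gives 0.383 h in this assay. Compound 2 `CC(Sc1nc2c(cnn2C)c(=O)n1-c1ccccc1)c1cccnc1`, built on the same shared core but with different groups around it, gives 0.117 h in this assay. Of these two numbers, compound 1 stands highest, and its gap to compound 2 is beyond the scatter, so compound 1 is the longer-lived of the pair.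

Compound 3 `CC(Sc1nc2nn(C3COC3)cc2c(=O)n1-c1ccccc1)c1ccccc1` has not yet been measured. It differs from compound 1 in one place only: 1-phenylethyl in place of 3-fluorobenzyl on a sulfur. Going by the values given here, no measured pair in this set shows the effect of this exact change, so the expectation rests on compound 1 alone. With one fluorine leaving and a carbon-bearing branch entering, a step of roughly the size of the scatter is expected in this assay, most likely toward a shorter half-life, given as a 1.3-fold lower number from compound 1 to compound 3 (0.11 log units; within the scatter). Compound 3 is accordingly estimated at 0.3 h, within a range from 0.12 h to 0.7 h.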

Compound 3, half-life: 0.783 h
Compound 3: the middle estimate sits 2.6-fold (0.42 log units) below what was measured; the measured number lies above the stated range.
By their numbers in this assay, from the lowest: compound 2; then compound 1; then compound 3.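

On the sulfur of the shared core, this position responds to a swap between two groups of equal heavy-atom count: in this assay, 1-phenylethyl in place of 3-fluorobenzyl gives a 2.0-fold higher number from compound 1 to compound 3 (0.31 log units; beyond the scatter) and so a longer-lived compound. The step is modest, but it shows that the fluorine of compound 1 is not needed for a longer half-life in this series, at least with 1-phenylethyl on the sulfur. Nothing measured here explains why the number rises.

The swap removes a fluorine and adds a carbon at once, so the compounds shown cannot say which of the two matters. A plain benzyl on the sulfur would separate them, while a longer chain such as 1-phenylpropyl would show whether the trend continues.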